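Acyl variation on the threonine dodecylamide series

This account rests on a few compounds, and the source may have more. Where it says the series, first, only, none or still open, it means among the compounds named here.

Compound 1 `CCCCCCCCCCCCNC(=O)[C@@H](NC(=O)c1ccco1)[C@@H](C)O` gives 147000 nM in a functional assay on HepG2 cells (Homo sapiens) for cytotoxicity, read by MTT assay, with a stated time of 48 h; on this read-out lower numbers stand for stronger inhibition and higher numbers for weaker inhibition. Compound 2 `CCCCCCCCCCCCNC(=O)[C@@H](NC(=O)c1cccs1)[C@@H](C)O` gives 30100 nM in this assay, and compound 3 `CCCCCCCCCCCCNC(=O)[C@@H](NC(=O)c1cc2ccccc2[nH]1)[C@@H](C)O` gives 12000 nM in this assay, the lowest number of the three. The steps were a 4.9-fold lower number from compound 1 to compound 2 (0.69 log units; beyond the scatter) and a 2.5-fold lower number from compound 2 to compound 3 (0.40 log units; beyond the scatter), all falling on the carbonyl carbon. Compound 4 `C/C=C/C=C/C(=O)N[C@H](C(=O)NCCCCCCCCCCCC)[C@@H](C)O` differs from compound 3 by penta-1,3-dien-1-yl in place of 1H-indol-2-yl on a carbonyl carbon. The steps of a 12-fold lower number from compound 1 to compound 3 (1.09 log units; beyond the scatter) and a 2.5-fold lower number from compound 2 to compound 3 (0.40 log units; beyond the scatter) bear on this position; both went toward lower numbers with a larger ring system at the carbonyl carbon, and removing the ring system altogether is expected to move the number back up by a modest to large step. The estimate for compound 4 in this assay is 45000 nM, range 12000 nM to 160000 nM, expected as a 3.8-fold higher number from compound 3 to compound 4 (0.57 log units; beyond the scatter).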

Compound 4, half-maximal inhibitory concentration: > 400000 nM
Compound 4: a limit, no number; the forecaster's own chance of this, stated with the estimate: 15%; middle value at least 8.8-fold (0.94 log units) away from the limit.
By their numbers in this assay, from the lowest: compound 3; then compound 2; then compound 1. At a limit, above all of these: compound 4.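

Compound 4 stands at a limit of the assay, not at a number: the limit of > 400000 nM in this assay, at which 1 of the 4 values shown sits. Penta-1,3-dien-1-yl on the carbonyl carbon gives an at least 33-fold higher number from compound 3 to compound 4 (1.52 log units; beyond the scatter) and an at least 13-fold higher number from compound 2 to compound 4 (1.12 log units; beyond the scatter) and also an at least 2.7-fold higher number from compound 1 to compound 4 (0.43 log units; beyond the scatter) in this series. The earlier compounds shown here compared ring groups only, whereas this open chain without a ring lies on the high side of all three, including furan-2-yl.

Whether the missing ring or the double bonds account for this stays open, and a saturated pentyl chain would separate the two. An amine or a carboxylic acid at this position also remains untested in the compounds shown.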